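The compounds below may be only part of what the source reports. "The series", "measured", "known", "first", "only" and "open" are said of these compounds alone.

In a functional assay on T47D cells (Homo sapiens) for inhibition (a higher number here means a weaker inhibitor, a lower number a stronger inhibitor), the shared core carries two hydroxyphenyl groups and a third aryl group, and moving the hydroxyl around the rings changes the outcome. Compound 1 `Oc1ccccc1-c1cc(-c2ccc(F)cc2)cc(-c2ccccc2O)n1` gives only a limit of the assay, > 50000 nM. Compound 2 `Oc1cccc(-c2cc(-c3ccc(F)cc3)cc(-c3ccccc3O)n2)c1` likewise gives only a limit, > 50000 nM. Compound 3 `Oc1ccc(-c2cc(-c3ccc(F)cc3)cc(-c3cccc(O)c3)n2)cc1` gives a measured number, 5000 nM. The step from compound 1 to compound 2 is a step that the two limits leave unreadable from compound 1 to compound 2, while the step from compound 2 to compound 3 is an at least 10-fold lower number from compound 2 to compound 3 (1.00 log units; beyond the scatter); both rest on (the limit of > 50000 nM in this assay, at which 2 of the 3 values shown sit), so compound 2 stands at the weak end of what has been seen.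

Compound 4 `Oc1cccc(-c2cc(-c3ccc(OC(F)(F)F)cc3)cc(-c3ccccc3O)n2)c1` keeps both hydroxyphenyl groups of compound 2 and differs only by trifluoromethoxy in place of fluoro on an aromatic carbon. Going by the values given here, none of the measured steps touches this position; they all move a hydroxyl, so none speaks directly to this change. Compound 4 is therefore expected to stay near the limit, with an estimated step that the limit leaves unreadable from compound 2 to compound 4. Compound 4 is estimated at 60000 nM, within 10000 nM to 300000 nM.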

Compound 4, half-maximal inhibitory concentration: 7710 nM
Estimate against measurement, compound 4: 7.8-fold (0.89 log units) above; the whole stated range lies above it.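

The position para to a large group, which carries the fluoro group, now proves able to change the outcome, whereas the earlier readable step moved a hydroxyl. In this assay, trifluoromethoxy in place of fluoro gives an at least 6.4-fold lower number from compound 2 to compound 4 (0.81 log units; beyond the scatter). Compound 2 has only a limit of the assay, > 50000 nM, so the full size of this step stays unknown because the starting point is not a true number: the limit of > 50000 nM in this assay, at which 2 of the 4 values shown sit.

The compounds shown do not tell whether this lower number belongs to trifluoromethoxy in particular, or whether a methoxy group, a chlorine atom or an amine at the same place would also give one. They also leave open whether the same change would lower the number for compound 3, whose hydroxyl groups sit elsewhere.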